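Swapping the imidazole for benzofuran in a cytotoxic scaffold

A few compounds are considered here, and "the series" means these few. Any claim that something is new, unique, unknown or untested is made for them only; others in the source may bear on it.

Compound 1 `CC(C)(C)c1[nH]cnc1/C=c1\[nH]c(=O)/c(=C/c2cccc(Oc3ccc(F)cc3)c2)[nH]c1=O` gives 4 nM in a functional assay on NCI-H460 cells (Homo sapiens) for cytotoxicity, read by MTT assay, with a stated time of 72 h (on this read-out higher numbers stand for weaker inhibition and lower numbers for stronger inhibition), the lowest number among the three compounds measured. Compound 2 `Cc1[nH]cnc1/C=c1\[nH]c(=O)/c(=C/c2cccc(Oc3ccc(F)cc3)c2)[nH]c1=O` gives 47.6 nM, and compound 3 `COCc1ccc(/C=c2\[nH]c(=O)/c(=C/c3cccc(Oc4ccc(F)cc4)c3)[nH]c2=O)o1` gives 14 nM. Compound 4 `O=c1[nH]/c(=C\c2cc3ccccc3o2)c(=O)[nH]/c1=C\c1cccc(Oc2ccc(F)cc2)c1` differs from compound 1 in one place: 1-benzofuran-2-yl in place of 5-(tert-butyl)-1H-imidazol-4-yl on a double-bonded chain carbon bound to an aromatic carbon. The closest guide is the step of a 3.5-fold higher number from compound 1 to compound 3 (0.54 log units; beyond the scatter), where the imidazole was likewise replaced by a furan-type ring; the step of a 12-fold higher number from compound 1 to compound 2 (1.08 log units; beyond the scatter) shows that trimming the imidazole itself also weakens inhibition. A modest rise in the number, beyond the scatter, is therefore expected for compound 4 in this assay, which would be a 4.5-fold higher number from compound 1 to compound 4 (0.65 log units; beyond the scatter). Compound 4 is estimated at 18 nM, expected to fall between 5 nM and 70 nM.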

Compound 4, half-maximal inhibitory concentration: 347 nM
Compound 4: the middle estimate sits 19-fold (1.29 log units) below what was measured; the whole stated range lies below it.
By their numbers in this assay, from the lowest: compound 1; then compound 3; then compound 2; then compound 4.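

In this assay, the 1-benzofuran-2-yl group proves far less well tolerated at this place than the furan of compound 3 suggested, and it gives the highest number of the four (an 87-fold higher number from compound 1 to compound 4 (1.94 log units; beyond the scatter); a 25-fold higher number from compound 3 to compound 4 (1.39 log units; beyond the scatter); a 7.3-fold higher number from compound 2 to compound 4 (0.86 log units; beyond the scatter)). Compound 3 and compound 4 both carry an oxygen-containing ring here, so such a ring alone does not keep the number low. No measurement shown explains this gap.

Going by these compounds, whether the loss follows the added six-membered ring or the missing methoxymethyl group stays open. An unsubstituted furan-2-yl at this place would help separate the two.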